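This account rests on a few compounds, and the source may have more. Where it says the series, first, only, none or still open, it means among the compounds named here.

Measured in a physicochemical assay for solubility, at pH 7; on this read-out lower numbers stand for lower solubility and higher numbers for higher solubility:

- Compound 1 `CNC(=O)c1cc(Oc2ccc3nc(Nc4cccc(Cl)c4)ncc3c2)ccn1`: < 1000 nM, a limit of the assay rather than a number.
- Compound 2 `CNC(=O)c1cc(Oc2ccc3nc(Nc4cccc(C(C)C)c4)ncc3c2)ccn1`: < 1000 nM, again only a limit.
- Compound 3 `CNC(=O)c1cc(Oc2ccc3nc(Nc4ccc(Br)cc4)ncc3c2)ccn1`: < 1000 nM, likewise a limit.

Compound 3 therefore stands at the lower limit of this assay, and it shares that position with the two other measured compounds, as all three sit at the limit of < 1000 nM in this assay, at which 3 of the 3 values shown sit. Because of this the three measured steps cannot be read: a step that the two limits leave unreadable from compound 1 to compound 2, a step that the two limits leave unreadable from compound 1 to compound 3 and a step that the two limits leave unreadable from compound 2 to compound 3. None of them tells how far any compound lies beneath the limit, so no size and no direction can be taken from them.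

Compound 4 `CNC(=O)c1cc(Oc2ccc3nc(Nc4ccc(Oc5ccccc5)cc4)ncc3c2)ccn1` is the next compound, not yet measured in this assay. It differs from compound 3 in one place: phenoxy in place of bromo on an aromatic carbon. The measured steps give no readable size to lean on, so the expectation rests only on where compound 3 stands, at the limit. For compound 4 the expected step from compound 3 is a step that the limit leaves unreadable from compound 3 to compound 4, which is to say no change beyond the scatter is expected. The estimated solubility of compound 4 in this assay is 300 nM, with a range from 50 nM to 1500 nM, and it is expected most likely to be reported again only as a limit.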

Compound 4, solubility: < 1000 nM
Compound 4 was reported as a limit; the forecaster's own chance of this, stated with the estimate: 90%; the middle value lies beyond the limit too.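

No step can be read from compound 3 to compound 4, since both are reported only as limits in this assay, a position shared by every compound shown: the limit of < 1000 nM in this assay, at which 4 of the 4 values shown sit.

As far as these compounds go, how far compound 1, compound 2, compound 3 or compound 4 lies beneath that limit stays open, and so does whether phenoxy in place of bromo makes any difference.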